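Fluoro in place of methoxy: notes on compound 2

The source may hold more compounds than are shown below. What is called first, only, known or untested is meant among the compounds shown, and "the series" means these compounds.

Measured in a functional assay on HL-60 cells (Homo sapiens) for inhibition, read by CCK-8 assay, with a stated time of 48 h, tested at 20 uM; a higher number here means more inhibition of growth at the concentration tested, a lower number less inhibition of growth:
- compound 1 `N#C/C(=C\c1ccccc1OS(=O)(=O)c1ccc(F)cc1)C(=O)Nc1nnc(Cc2ccc(F)cc2)s1` gives 13%
- compound 2 `COc1ccc(S(=O)(=O)Oc2ccccc2/C=C(\C#N)C(=O)Nc2nnc(Cc3ccc(C)cc3)s2)cc1` gives 100%

Compound 2 holds the higher of the two numbers, and compound 1 lies below it by a gap beyond the scatter. Compound 3 `Cc1ccc(Cc2nnc(NC(=O)/C(C#N)=C/c3ccccc3OS(=O)(=O)c3ccc(F)cc3)s2)cc1` is still unmeasured in this assay. It departs from compound 2 at one place: fluoro in place of methoxy on an aromatic carbon. This is fluoro in place of methoxy on an aromatic carbon, para to a large group, so 4-methoxyphenyl becomes 4-fluorophenyl. For the measured compounds named here, no measured pair differs at only one place, so the size of this change cannot be read directly from the data. Going by the values given here, only two readings exist, and compound 1 at 13% shows that low values occur in this small set. Compound 2 at 100% leaves room mainly for a fall, so a downward move beyond the scatter is expected, with wide uncertainty. The expected change is a number 45 percentage points lower from compound 2 to compound 3 (beyond the scatter). For compound 3 the estimated value is 55%, within an expected range of 15% to 100%.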

Compound 3, percent growth inhibition at one concentration: 11%
Beside the measured number, compound 3's estimate is 44 percentage points above it; the whole stated range lies above it.
By their numbers in this assay, from the lowest: compounds 3 and 1 (each within the scatter of the next); then compound 2.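

In this assay, the change from 4-methoxyphenyl to 4-fluorophenyl gives a number 89 percentage points lower from compound 2 to compound 3 (beyond the scatter), so this single place, on an aromatic carbon para to a large group, can carry a large step in this series. The second single-place pair, with methyl in place of fluoro on an aromatic carbon elsewhere in the molecule, gives a number 2 percentage points lower from compound 1 to compound 3 (within the scatter), so with 4-fluorophenyl present that exchange leaves the reading within the scatter. Nothing available bears on the reason for the large step.

As far as these compounds go, it remains open whether the second exchange would also stay within the scatter with 4-methoxyphenyl present. Also open, from the compounds shown here alone, is how a hydroxy group, an amino group or a longer ethoxy chain would read on the aromatic carbon that carries the methoxy group in compound 2.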